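The source may report more compounds than this note shows. Statements on the series, on what has been measured and on what is new or still open speak of the compounds shown alone.

Measured compounds, with their half-maximal cytotoxic concentrations in a functional assay on CCRF-CEM cells (Homo sapiens); on this read-out lower numbers stand for higher toxicity in this test and higher numbers for lower toxicity in this test:

Compound 1, `CCNC(=O)NC1=CS(=O)(=O)O[C@@]12[C@@H](CO[Si](C)(C)C(C)(C)C)O[C@@H](n1cc(C)c(=O)n(C)c1=O)[C@@H]2O[Si](C)(C)C(C)(C)C`: 4260 nM
Compound 2, `Cc1cn([C@@H]2O[C@H](CO[Si](C)(C)C(C)(C)C)[C@@]3(OS(=O)(=O)C=C3NC(=O)c3ccccc3)[C@H]2O[Si](C)(C)C(C)(C)C)c(=O)n(C)c1=O`: 4910 nM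
Compound 3, `Cc1cn([C@@H]2O[C@H](CO[Si](C)(C)C(C)(C)C)[C@@]3(OS(=O)(=O)C=C3NC(N)=O)[C@H]2O[Si](C)(C)C(C)(C)C)c(=O)n(C)c1=O`: 4360 nM

All three numbers lie within the usual scatter of one another, so compound 3 cannot be set apart from the others: a 1.0-fold higher number from compound 1 to compound 3 (0.01 log units; within the scatter) and a 1.1-fold lower number from compound 2 to compound 3 (0.05 log units; within the scatter). Compound 4, `Cc1cn([C@@H]2O[C@H](CO[Si](C)(C)C(C)(C)C)[C@@]3(OS(=O)(=O)C=C3NCCC(=O)O)[C@H]2O[Si](C)(C)C(C)(C)C)c(=O)n(C)c1=O`, carries the change (2-carboxyethyl in place of carbamoyl on an amine nitrogen). The two measured steps touching the same nitrogen, a 1.0-fold higher number from compound 1 to compound 3 (0.01 log units; within the scatter) and a 1.1-fold lower number from compound 2 to compound 3 (0.05 log units; within the scatter), were both flat, and a 1.2-fold higher number from compound 1 to compound 2 (0.06 log units; within the scatter) likewise. No step beyond the scatter is therefore expected in this assay for compound 4, although this change goes further than any of the measured ones. Compound 4 is estimated to give 4400 nM, with a likely range from 2000 nM to 9500 nM, meaning a 1.0-fold higher number from compound 3 to compound 4 (0.00 log units; within the scatter).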

Compound 4, half-maximal cytotoxic concentration: 19400 nM
For compound 4 the middle estimate is 4.4-fold (0.64 log units) below the measured one; the whole stated range lies below it.
By their numbers in this assay, from the lowest: compounds 1, 3 and 2 (each within the scatter of the next); then compound 4.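

In this assay, going by these compounds alone, the substituent on this amine nitrogen does matter: 2-carboxyethyl in place of carbamoyl gives the first step beyond the scatter (a 4.4-fold higher number from compound 3 to compound 4 (0.65 log units; beyond the scatter)). The same holds against benzoyl (a 4.0-fold higher number from compound 2 to compound 4 (0.60 log units; beyond the scatter)) and against ethylcarbamoyl (a 4.6-fold higher number from compound 1 to compound 4 (0.66 log units; beyond the scatter)), so 2-carboxyethyl stands apart from all three groups that join this nitrogen through a carbonyl. No supporting data bear on the reason for this difference. From the compounds shown here alone, whether the step belongs to the carboxylic acid or to the chain stays open; a matching methyl ester or a plain propyl group on this nitrogen would separate the two.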